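Aryl amide replaced by an ethyl oxalamide on the chalcone

The source may report more compounds than this note shows. Statements on the series, on what has been measured and on what is new or still open speak of the compounds shown alone.

Measured so far:
compound 1, `COc1cc(/C=C/C(=O)c2cccc(NC(=O)c3c(Cl)cccc3Cl)c2)ccc1O`: 88%
compound 2, `COc1cc(/C=C/C(=O)c2cccc(NC(=O)c3ccc(Cl)cc3Cl)c2)ccc1O`: 51%

Both compounds were tested in a functional assay on HUVEC cells (Homo sapiens) for inhibition, tested at 5 ug/mL; on this read-out lower numbers stand for a weaker effect and higher numbers for a stronger effect at the one concentration tested. Among the measured compounds shown here, compound 2 has the lower of the two numbers; the only measured step, a number 37 percentage points lower from compound 1 to compound 2 (beyond the scatter), separates it from compound 1. For the measured compounds named here, that step is the sole guide available, and it touches only the chlorine pattern on the same ring, not the removal of the ring itself.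

Compound 3, `CCOC(=O)C(=O)Nc1cccc(C(=O)/C=C/c2ccc(O)c(OC)c2)c1`, is not yet measured. It differs from compound 2 by ethoxycarbonyl in place of 2,4-dichlorophenyl on a carbonyl carbon. Going by the values given here, no measured step mirrors this exchange, so the direction cannot be read from the data; the large size of the step from compound 1 to compound 2 only shows that changes at this amide position can move the read-out a lot. Compound 3 is therefore expected at 35%, within 5% to 70%. The expected step is a number 16 percentage points lower from compound 2 to compound 3 (beyond the scatter).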

Compound 3, a percentage reported as inhibition, at one concentration (the size of the read-out at that concentration, not a potency): 45%
Compound 3: the middle estimate sits 10 percentage points below what was measured; the measured number falls inside the stated range.
By their numbers in this assay, from the lowest: compounds 3 and 2 (each within the scatter of the next); then compound 1.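

In this assay the change gives a number 6 percentage points lower from compound 2 to compound 3 (within the scatter) even though a 2,4-dichlorophenyl, with its ring and two chlorines, gives way to a ring-free ethoxycarbonyl. Set against the 2,6-dichlorophenyl, the same ethoxycarbonyl gives a number 43 percentage points lower from compound 1 to compound 3 (beyond the scatter) and this large step shows that having an aromatic ring on this carbonyl carbon does not by itself set a compound apart, since compound 2 has one and cannot be told from compound 3. No measurement here explains why compound 1 stands apart.

Open, going by these compounds, is whether a carboxylic acid in place of the ethyl ester, or a longer chain, would stay with compound 2 and compound 3 or move towards compound 1. Also open, on these data alone, is whether a 2,6-dimethylphenyl on this carbonyl carbon would keep the high number of compound 1.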